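Adding two methyls to the azetidine ring of compound 3

This account rests on a few compounds, and the source may have more. Where it says the series, first, only, none or still open, it means among the compounds named here.

Compound 1, `CCC(Nc1ccc(S(=O)(=O)Nc2nccs2)cc1Cl)c1ccccc1`, gives 50 nM in an assay on HEK293 cells for inhibition of SCN8A/SCN1B (Homo sapiens), read by patch clamp, with a stated time of 20 min; a higher number here means a weaker inhibitor, a lower number a stronger inhibitor.
Compound 2, `CCC(c1ccccc1)N(C)c1ccc(S(=O)(=O)Nc2nccs2)cc1Cl`, gives 1410 nM in this assay.
Compound 3, `O=S(=O)(Nc1cscn1)c1cc(Cl)c(NCc2c(F)cccc2CN2CCC2)cc1F`, gives 30 nM in this assay.

Compound 3 gives the lowest number of the three, but compound 1 sits within the usual scatter of it, so the two cannot be ranked; compound 2 is clearly weaker than both. Going by the values given here, the only single change measured so far is a 28-fold higher number from compound 1 to compound 2 (1.45 log units; beyond the scatter), a large step, but it concerns a hydrogen on a nitrogen attached to an aromatic ring, not the saturated ring that changes here.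

Compound 4, `CC1(C)CCN1Cc1cccc(F)c1CNc1cc(F)c(S(=O)(=O)Nc2cscn2)cc1Cl`, differs from compound 3 by 2,2-dimethylazetidin-1-yl in place of azetidin-1-yl on a saturated chain carbon bound to an aromatic carbon. Among the compounds with values here, no measured pair bears on this change, so the expectation rests on the absence of evidence rather than on a known step: two methyls on a ring far from the sulfonamide seem unlikely to move the number much. The expected step is a 1.2-fold higher number from compound 3 to compound 4 (0.07 log units; within the scatter), within the scatter. Compound 4 is therefore estimated at 35 nM, with a likely range from 12 nM to 100 nM.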

Compound 4, half-maximal inhibitory concentration in the SCN8A/SCN1B assay: 230 nM
Estimate against measurement, compound 4: 6.6-fold (0.82 log units) below; the whole stated range lies below it.
By their numbers in the SCN8A/SCN1B assay, from the lowest: compounds 3 and 1 (each within the scatter of the next); then compound 4; then compound 2.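

In the SCN8A/SCN1B assay, adding the two methyls gives a 7.7-fold higher number from compound 3 to compound 4 (0.88 log units; beyond the scatter), so 2,2-dimethylazetidin-1-yl is a clearly weaker replacement for azetidin-1-yl, and a small addition to this saturated ring does matter. Going by these compounds alone, the earlier compounds could not show this, since their only measured step concerned a hydrogen on a nitrogen attached to an aromatic ring. In a physicochemical assay for lipophilicity, read by LC-MS, in phosphate buffer, measured as octanol-water partition, with a stated time of 1 h, at pH 7.4 (on this read-out lower numbers stand for lower lipophilicity and higher numbers for higher lipophilicity), compound 3 gives 2.6 and compound 4 gives 3, so the same change also comes with higher lipophilicity: the measured distribution coefficient of compound 3, 2.6, and of compound 4, 3, a number 0.40 log units higher (beyond the scatter)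

This single pair cannot tell whether that rise in lipophilicity is connected to the weaker inhibition. Still open, on these data alone, is how 2-methylazetidin-1-yl, with its single methyl, or a pyrrolidin-1-yl ring or an open-chain dimethylamino group would behave on this saturated chain carbon bound to an aromatic carbon.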